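Shortening the chain and switching its end group

The source may report more compounds than this note shows. Statements on the series, on what has been measured and on what is new or still open speak of the compounds shown alone.

Compound 1 `CNC(=O)CCCCCCCNC(=O)c1cccc(-n2c(-c3cc(C(C)C)c(O)cc3O)n[nH]c2=O)c1` carries on its core a chain that ends in a 3-(methylcarbamoyl)propyl group, whereas compound 2 `CC(C)c1cc(-c2n[nH]c(=O)n2-c2ccc(C(=O)NCCCC(=O)NO)cc2)c(O)cc1O` and compound 3 `CC(C)c1cc(-c2n[nH]c(=O)n2-c2ccc(C(=O)NCCCCCCC(=O)NO)cc2)c(O)cc1O` carry chains that end in hydroxycarbamoyl. In a functional assay on A549 cells (Homo sapiens) for inhibition (on this read-out lower numbers stand for stronger inhibition and higher numbers for weaker inhibition), compound 1 gives 4600 nM, compound 2 gives 4600 nM and compound 3 gives 4600 nM. Compound 1 therefore stands level with both others at the digits given; compound 2 is its nearest neighbour and compound 3 its furthest, and neither gap exceeds the scatter. Among the measured compounds shown here, the only single-point step among the measured compounds, no change at the digits printed from compound 2 to compound 3 (within the scatter), tells that lengthening the hydroxycarbamoyl-bearing chain left the read-out where it was.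

Compound 4 `CC(C)c1cc(-c2n[nH]c(=O)n2-c2cccc(C(=O)NCCCCC(=O)NO)c2)c(O)cc1O` differs from compound 1 by hydroxycarbamoyl in place of 3-(methylcarbamoyl)propyl on a saturated chain carbon, four bonds along the chain from an amide-type nitrogen. The step from compound 2 to compound 3 bears on this change from the side of chain length, and the pair of values of compound 1 and compound 2 bears on it from the side of the end group; both show nothing beyond the scatter. He accordingly expects no step beyond the scatter, no change at the digits printed from compound 1 to compound 4 (within the scatter). His estimate for compound 4 in this assay is 4600 nM, expected to fall between 1800 nM and 12000 nM.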

Compound 4, half-maximal inhibitory concentration: 4600 nM
For compound 4 middle estimate and measured number coincide at the digits printed; the measured number falls inside the stated range.
By their numbers in this assay, from the lowest: compounds 1, 2, 3 and 4 (each within the scatter of the next).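

In this assay, putting hydroxycarbamoyl in place of 3-(methylcarbamoyl)propyl on a saturated chain carbon, four bonds along the chain from an amide-type nitrogen, gives no change at the digits printed from compound 1 to compound 4 (within the scatter). Among the compounds shown here, the one earlier step altered only the length of a chain already ending in hydroxycarbamoyl, whereas this step replaces the end of the chain itself, and at this position the read-out does not tell the two groups apart. Nothing measured here bears on why the read-out stays level across this exchange.

The compounds shown leave open whether a carboxylic acid or a primary amine at the end of the chain, or a longer chain, would move the value in this assay beyond the scatter. All four compounds stand within the scatter of one another, and they do not tell whether this read-out responds to any part of the chain or its end group.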